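A few compounds are considered here, and "the series" means these few. Any claim that something is new, unique, unknown or untested is made for them only; others in the source may bear on it.

Measured in a functional assay on A2780 cells (Homo sapiens) for inhibition, read by sulforhodamine B assay; on this read-out higher numbers stand for weaker inhibition of growth and lower numbers for stronger inhibition of growth:
- compound 1 `Cc1ccc2[nH]c(-c3ccc(-c4ccc(-c5cccc(Cl)c5)cc4)cc3)nc2c1`: 2800 nM
- compound 2 `COc1ccc(-c2ccc(-c3ccc(-c4nc5cc(C)ccc5[nH]4)cc3)cc2)cc1OC`: 2130 nM
- compound 3 `Clc1cccc(-c2ccc(-c3ccc(-c4nc5ccccc5[nH]4)cc3)cc2)c1`: 31100 nM

Compound 2 stands at the low end of these numbers, but it cannot be separated from its closest neighbour: the record shows a 1.3-fold lower number from compound 1 to compound 2 (0.12 log units; within the scatter). Compound 3 has the highest number, at 31100 nM.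

The next compound, compound 4 `COc1ccc(-c2ccc(-c3ccc(-c4nc5ccccc5[nH]4)cc3)cc2)cc1OC`, is reached by hydrogen in place of methyl on an aromatic carbon. This is hydrogen in place of methyl on an aromatic carbon, so 5-methyl-1H-benzimidazol-2-yl becomes 1H-benzimidazol-2-yl.

The same change has been measured once, as a large step: an 11-fold higher number from compound 1 to compound 3 (1.05 log units; beyond the scatter). The other measured step bears on whether it should carry over, since exchanging the outer group made no difference beyond the scatter: a 1.3-fold lower number from compound 1 to compound 2 (0.12 log units; within the scatter). A clear rise in this assay is therefore expected, though one pair is thin support, so a somewhat smaller step is allowed for.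

The expected change is a 6.1-fold higher number from compound 2 to compound 4 (0.79 log units; beyond the scatter).

Compound 4 is estimated at 13000 nM, with an expected range of 4500 nM to 35000 nM.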

Compound 4, concentration for 50% growth inhibition: 21600 nM
Estimate against measurement, compound 4: 1.7-fold (0.22 log units) below; the range from low to high includes it.
By their numbers in this assay, from the lowest: compounds 2 and 1 (each within the scatter of the next); then compounds 4 and 3 (each within the scatter of the next).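

Removing the methyl in this assay gives a 10-fold higher number from compound 2 to compound 4 (1.01 log units; beyond the scatter), so the large step now appears with 3,4-dimethoxyphenyl as the outer group as well as with 3-chlorophenyl, and its size repeats closely: the same change on two cores in this assay, an 11-fold higher number (1.05 log units; beyond the scatter) from compound 1 to compound 3 and a 10-fold higher number (1.01 log units; beyond the scatter) from compound 2 to compound 4, 1.1-fold (0.04 log units) apart, within the scatter of two such steps

Exchanging the outer group on the core without the methyl gives a 1.4-fold lower number from compound 3 to compound 4 (0.16 log units; within the scatter), so this exchange leaves the number unchanged within the scatter with or without the methyl: the same change on two cores in this assay, a 1.3-fold lower number (0.12 log units; within the scatter) from compound 1 to compound 2 and a 1.4-fold lower number (0.16 log units; within the scatter) from compound 3 to compound 4, 1.1-fold (0.04 log units) apart, within the scatter of two such steps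

Across these four compounds, the number therefore follows the methyl and not the outer group, and no compound shown goes against this.

The compounds shown compare only methyl and hydrogen at this carbon, so they leave open whether an ethyl group, a methoxy group or an amine there would give a lower number than methyl. They also leave open whether a carboxylic acid on the outer group would shift the number.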